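Phenyl to 2-methoxyphenyl: the step from compound 2

This account rests on a few compounds, and the source may have more. Where it says the series, first, only, none or still open, it means among the compounds named here.

In a functional assay on MCF7 cells (Homo sapiens) for inhibition, with a stated time of 72 h (on this read-out higher numbers stand for weaker inhibition and lower numbers for stronger inhibition), compound 1 `NC1CCC(Nc2nc(NCc3ccc(Br)cc3)c3ncn(C4CCCC4)c3n2)CC1` gives 850 nM and compound 2 `NC1CCC(Nc2nc(NCc3ccc(-c4ccccc4)cc3)c3ncn(C4CCCC4)c3n2)CC1` gives 583 nM. Within the data shown here, compound 2 therefore stands level with compound 1, the only other measured compound, since their two numbers lie within the scatter of each other.

Compound 3 `COc1ccccc1-c1ccc(CNc2nc(NC3CCC(N)CC3)nc3c2ncn3C2CCCC2)cc1` carries phenyl to 2-methoxyphenyl: methoxy in place of hydrogen on an aromatic carbon. In words, this is methoxy in place of hydrogen on an aromatic carbon, ortho to a large group.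

Among the measured compounds shown here, only one measured step bears on this change: a 1.5-fold lower number from compound 1 to compound 2 (0.16 log units; within the scatter), with phenyl in place of bromo on an aromatic carbon. For the measured compounds named here, that step lies within the scatter, and it is only indirect evidence, as no measured pair shows methoxy in place of hydrogen. With so little evidence, no direction can be assigned, and no shift beyond the scatter is expected in this assay. The expected change is a 1.0-fold higher number from compound 2 to compound 3 (0.01 log units; within the scatter). For compound 3 the estimated value is 600 nM, with an expected range of 250 nM to 1400 nM.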

Compound 3, half-maximal inhibitory concentration: 303 nM
Estimate against measurement, compound 3: 2.0-fold (0.30 log units) above; measured number inside the range.
By their numbers in this assay, from the lowest: compounds 3, 2 and 1 (each within the scatter of the next, the first and the last beyond it).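

In this assay, among these compounds, methoxy in place of hydrogen on an aromatic carbon, ortho to a large group, gives a 1.9-fold lower number from compound 2 to compound 3 (0.28 log units; within the scatter); this is the first direct pair on the change, and it shows that the position accepts methoxy with no loss beyond the scatter, but it does not establish a gain. The wider replacement of bromo by 2-methoxyphenyl gives a 2.8-fold lower number from compound 1 to compound 3 (0.45 log units; beyond the scatter), the only step shown that lies beyond the scatter, and it is modest, while the single replacement of bromo by phenyl gives a 1.5-fold lower number from compound 1 to compound 2 (0.16 log units; within the scatter), so the separation between compound 1 and compound 3 appears only with both changes taken together. No measurement in hand gives a reason for either step.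

From the compounds shown here alone, it remains open whether the methoxy group itself matters at this place, or whether a hydroxyl, an ethoxy group, a fluorine atom or a longer ether chain would read the same in this assay. Also open, going by these compounds, is how an amine or a carboxylic acid would read at this place, and whether methoxy would give a similar step elsewhere on the same ring.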